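The compounds below may be only part of what the source reports. "The series", "measured", "known", "first", "only" and "open" are said of these compounds alone.

Measured compounds: compound 1 `O=C(Nc1cccc(C(F)(F)F)c1)N[C@H]1CC[C@H](Oc2cccc(F)c2)CC1` gives 2400 nM in a functional assay on CRL2813 cells (Homo sapiens) for cytotoxicity, read by sulforhodamine B assay, with a stated time of 5 days; a higher number here means a weaker inhibitor, a lower number a stronger inhibitor; compound 3 `O=C(Nc1cccc(C(F)(F)F)c1)N[C@H]1CC[C@H](Oc2ccccc2F)CC1` gives 2450 nM; compound 2 `Cc1ccc(NC(=O)N[C@H]2CC[C@H](Oc3ccc(F)cc3)CC2)cc1` reaches only a limit of the assay, > 20000 nM. Compound 2 therefore stands at the weak end of the numbers shown, with no exact value, as the limit of > 20000 nM in this assay, at which 1 of the 3 values shown sits, records.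

Compound 4 `COc1cccc(NC(=O)N[C@H]2CC[C@H](Oc3ccc(F)cc3)CC2)c1` differs from compound 2 in one place: 3-methoxyphenyl in place of 4-methylphenyl on an amide-type nitrogen.

Among the compounds with values here, the only measured step, a 1.0-fold higher number from compound 1 to compound 3 (0.01 log units; within the scatter), concerns the fluorophenyl on the oxygen, not the aryl group on the urea nitrogen, so no measured step bears on this change. Compound 4 is expected to stay near the weak end, with an estimated value of 15000 nM (range 5000 nM to 40000 nM). The step of an at least 1.3-fold lower number from compound 2 to compound 4 (0.12 log units; that floor lies within the scatter) is thus expected to be small or to remain beyond the reach of the assay.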

Compound 4, half-maximal inhibitory concentration: 14000 nM
Compound 4: middle estimate off by 1.1-fold (0.03 log units), on the high side; the measured number falls inside the stated range.
By their numbers in this assay, from the lowest: compounds 1 and 3 (each within the scatter of the next); then compound 4. At a limit, above all of these: compound 2.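

With 3-methoxyphenyl on the amide-type nitrogen, compound 4 gives a number that can be read in this assay, which compound 2 does not provide. The change is an at least 1.4-fold lower number from compound 2 to compound 4 (0.15 log units; that floor lies within the scatter), so a real gain at this position is possible but not shown, and its true size is unknown. Compound 2 has only a limit, not a number: the limit of > 20000 nM in this assay, at which 1 of the 4 values shown sits.

The change alters both the group and its place on the ring, and a 3-methylphenyl at this nitrogen would tell those two apart. On these data alone, what an amine on that ring would give also stays open.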